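Compound 4 Expected to Remain at the Assay Limit

The source may report more compounds than this note shows. Statements on the series, on what has been measured and on what is new or still open speak of the compounds shown alone.

Compound 1 `Cc1ccc(NC(=O)Nc2cc(C)nc3ccccc23)cc1` sits at a limit in an ADME assay on HepG2 cells (Homo sapiens) for cytotoxicity, with a stated time of 72 h; on this read-out higher numbers stand for an effect only at larger amounts of compound and lower numbers for an effect already at smaller amounts: compound 1 gives > 25000 nM, which is a limit of the assay rather than a number. Compound 2 `Cc1cc(NC(=O)Nc2ccc(N(C)C)cc2)c2ccccc2n1` likewise reaches only a limit, > 25000 nM. Compound 3 `Cc1cc(NC(=O)Nc2ccc(SC(F)(F)F)cc2)c2ccccc2n1` gives 20000 nM. The step that the two limits leave unreadable from compound 1 to compound 2 cannot be read, and the step of an at least 1.2-fold lower number from compound 1 to compound 3 (0.09 log units; that floor lies within the scatter) lies within the scatter; both exchange the methyl on an aromatic carbon, whereas compound 4 `Cc1cc(NC(=O)Nc2cccc(Cl)c2)c2ccccc2n1` differs from compound 1 by 3-chlorophenyl in place of 4-methylphenyl on an amide-type nitrogen. No measured step touches that part, so nothing among the shown values points to an effect beyond the scatter, and the limit of > 25000 nM in this assay, at which 2 of the 3 values shown sit, marks where most values sit. Compound 4 is therefore expected to give 30000 nM (between 15000 nM and 60000 nM). The step that the limit leaves unreadable from compound 1 to compound 4 is expected to stay within the scatter.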

Compound 4, half-maximal effective concentration: 19000 nM
Compound 4: the middle estimate sits 1.6-fold (0.20 log units) above what was measured, within the range that was stated.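

Compound 4 is the first compound shown to carry chlorine, as 3-chlorophenyl in place of 4-methylphenyl on an amide-type nitrogen, and in this assay it gives a number rather than a limit. The exchange gives an at least 1.3-fold lower number from compound 1 to compound 4 (0.11 log units; that floor lies within the scatter), so it shows no effect beyond the scatter, and the limit on compound 1 leaves its full size unread. Limits still mark much of the set: the limit of > 25000 nM in this assay, at which 2 of the 4 values shown sit.

From the compounds shown here alone, what an amine or a carboxylic acid in place of the chlorine would give in this assay stays open, as does the effect of any change on the shared core.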